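From methyl to chloro: a single ring substituent exchanged

The source may hold more compounds than are shown below. What is called first, only, known or untested is meant among the compounds shown, and "the series" means these compounds.

Of the compounds shown here, three sharing one core have been tested in a functional assay on the whole organism for inhibition, with Rattus norvegicus as the target, read by paw edema, with a stated time of 30 min, at a dose of 80 mg/kg by the oral route; on this read-out higher numbers stand for a stronger effect at the one dose given and lower numbers for a weaker effect. Compound 1 `COc1ccc(OCC2=NCCO2)cc1` gives 64.1%, compound 2 `Brc1ccccc1OCC1=NCCO1` gives 62.8%, and compound 3 `Cc1ccccc1OCC1=NCCO1` gives 55.3%. Compound 3 carries the smallest of the three numbers written down, yet neither of the other two is separated from it by more than the usual scatter: compound 2 lies nearest and compound 1 furthest, both within the scatter.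

Compound 4 `Clc1ccccc1OCC1=NCCO1` differs from compound 3 in one place: chloro in place of methyl on an aromatic carbon. The change sits on an aromatic carbon of a six-membered aromatic ring of carbon only, ortho to a group of 7 heavy atoms.

For the measured compounds named here, only one measured step touches this position. It runs a number 7.5 percentage points lower from compound 2 to compound 3 (within the scatter), bromo to methyl, and did not exceed the scatter. Going by the values given here, a single change at the same carbon thus left the read-out essentially unmoved, and nothing among the measured compounds points the other way. The step from compound 3 to compound 4 is therefore expected to be small, around a number 4.7 percentage points higher from compound 3 to compound 4 (within the scatter), with no direction beyond the scatter. Compound 4 is estimated at 60% in this assay, in a range from 48% to 72%.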

Compound 4, a percentage reported as inhibition, in the whole organism at one dose (the size of the read-out at that dose, not a potency): 45.5%
Compound 4: middle estimate off by 14.5 percentage points, on the high side, outside the stated range (below it).
By their numbers in this assay, from the lowest: compounds 4, 3, 2 and 1 (each within the scatter of the next, the first and the last beyond it).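

In this assay, this position now gives its first step beyond the scatter: chloro in place of bromo on the aromatic carbon gives a number 17.3 percentage points lower from compound 2 to compound 4 (beyond the scatter). For the compounds shown here, the read-out at this carbon therefore depends on which of these two halogens it carries, a difference the earlier compounds could not show, since their only step here stayed within the scatter. Chloro in place of methyl, by contrast, gives a number 9.8 percentage points lower from compound 3 to compound 4 (within the scatter), so that exchange is not separated from the scatter, and nothing shown here offers an explanation for either step.

The compounds shown leave open how a fluoro group, an amine or a carboxylic acid on this same aromatic carbon would read, and so whether the separation between bromo and chloro belongs to a wider trend or stands alone. They also leave open whether that separation would hold at another carbon of the ring, or at other doses and times in the same kind of test, since a single dose gives the size of an effect and not a potency.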